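A Benzylic Swap Watched in a Cytotoxicity Series

The source may report more compounds than this note shows. Statements on the series, on what has been measured and on what is new or still open speak of the compounds shown alone.

Compound 1 `Cc1cc(N2CC[C@@H](C)[C@@H](N(C)c3ncnc4[nH]ccc34)C2)n2nc(SCC3CC3)nc2n1` is the point of departure. In a toxicity assay on GES1 cells (Homo sapiens) for inhibition, read by MTT assay, with a stated time of 72 h (a lower number here means a stronger inhibitor, a higher number a weaker inhibitor), compound 1 gives 27900 nM, the lowest of the two numbers reported, and compound 2 `Cc1nc2nc(SCc3ccc(Cl)cc3)nn2c(N2CC[C@@H](C)[C@@H](N(C)c3ncnc4[nH]ccc34)C2)c1C` gives 99200 nM, a value that lies beyond the usual scatter above it. Compound 3 `CCc1cc(N2CC[C@@H](C)[C@@H](N(C)c3ncnc4[nH]ccc34)C2)n2ncnc2n1` reaches only a limit of this assay, > 100000 nM. That is the limit of > 100000 nM in this assay, at which 1 of the 3 values shown sits. Compound 4 `COc1ccc(CSc2nc3nc(C)cc(N4CC[C@@H](C)[C@@H](N(C)c5ncnc6[nH]ccc56)C4)n3n2)cc1` has not yet been tested in this assay. It differs from compound 1 by 4-methoxyphenyl in place of cyclopropyl on a saturated chain carbon bound to a sulfur. Within the data shown here, with no single-change pair available to lean on, the step from compound 1 to compound 4 is expected to move modestly toward a weaker inhibitor, possibly staying within the scatter. Compound 4 is estimated at 50000 nM, with a range from 20000 nM to 150000 nM, meaning an expected step of a 1.8-fold higher number from compound 1 to compound 4 (0.25 log units; within the scatter).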

Compound 4, half-maximal inhibitory concentration: > 100000 nM
Compound 4 ended at the assay's limit; the forecaster's own chance of this, stated with the estimate: 35%; at least 2.0-fold (0.30 log units) between middle value and limit.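

The replacement of cyclopropyl by 4-methoxyphenyl on a saturated chain carbon bound to a sulfur gives the only single-change pair shown, and in this assay it reads as an at least 3.5-fold higher number from compound 1 to compound 4 (0.55 log units; beyond the scatter). This change at this position therefore moves the read-out toward a weaker inhibitor, beyond the scatter. Its full size cannot be read, because compound 4 stands at a limit and not at a number: the limit of > 100000 nM in this assay, at which 2 of the 4 values shown sit.

The compounds shown leave open whether the aromatic ring or its methoxy group carries the step, and whether a plain phenyl or an amine in that place would read the same.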